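Lengthening a Hydroxyalkyl Chain on a Shared Core

This account rests on a few compounds, and the source may have more. Where it says the series, first, only, none or still open, it means among the compounds named here.

Measured so far:
Compound 1 `Nc1ncc(-c2cccc(Cl)c2)c(-c2ccccc2)n1`: 55 nM
Compound 2 `Clc1cccc(-c2cnc(NC3CCCC3)nc2-c2ccccc2)c1`: 94 nM
Compound 3 `OCCCNc1ncc(-c2cccc(Cl)c2)c(-c2ccccc2)n1`: 59 nM

These three compounds share one core and differ only in the group on a nitrogen on an aromatic ring. In an assay on CHO cells for displacement of a labelled ligand from adenosine receptor A1 (Homo sapiens), read by scintillation counting, with a stated time of 1 h (on this read-out higher numbers stand for weaker inhibition and lower numbers for stronger inhibition), compound 1 gives 55 nM. Compound 2 gives 94 nM, and compound 3 gives 59 nM. On these numbers compound 3 stands second highest; its nearest neighbour is compound 1 and its furthest is compound 2, yet every step between the three is within the scatter: a 1.7-fold higher number from compound 1 to compound 2 (0.23 log units; within the scatter), a 1.1-fold higher number from compound 1 to compound 3 (0.03 log units; within the scatter) and a 1.6-fold lower number from compound 2 to compound 3 (0.20 log units; within the scatter).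

Compound 4 `OCCCCNc1ncc(-c2cccc(Cl)c2)c(-c2ccccc2)n1` has not yet been measured. It differs from compound 3 by hydroxymethyl in place of hydroxy on a saturated chain carbon, three bonds along the chain from a nitrogen on an aromatic ring. Among the compounds with values here, the steps that bear on this are the three swaps on that nitrogen, from hydrogen to cyclopentyl, from hydrogen to 3-hydroxypropyl and from cyclopentyl to 3-hydroxypropyl, and none of them moved the number beyond the scatter. Adding one chain carbon is a smaller alteration than any of those swaps, so no step beyond the scatter is expected in this assay. The expected step is a 1.0-fold higher number from compound 3 to compound 4 (0.01 log units; within the scatter). Compound 4 is therefore estimated at 60 nM, with a range from 25 nM to 150 nM.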

Compound 4, inhibition constant: 130 nM
For compound 4 the middle estimate is 2.2-fold (0.34 log units) below the measured one; measured number inside the range.
By their numbers in this assay, from the lowest: compounds 1, 3, 2 and 4 (each within the scatter of the next, the first and the last beyond it).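

In this assay, within the data shown here, hydroxymethyl in place of hydroxy on a saturated chain carbon, three bonds along the chain from a nitrogen on an aromatic ring, gives a 2.2-fold higher number from compound 3 to compound 4 (0.34 log units; beyond the scatter) and is the first step to pass beyond the scatter, though only modestly. Swapping hydrogen for 4-hydroxybutyl on that nitrogen also passes beyond it, as a 2.4-fold higher number from compound 1 to compound 4 (0.37 log units; beyond the scatter) shows, whereas swapping cyclopentyl for 4-hydroxybutyl does not, with a 1.4-fold higher number from compound 2 to compound 4 (0.14 log units; within the scatter), so the length of the hydroxyalkyl chain can shift this number even though the earlier swaps on the same nitrogen did not. No measurement on hand explains why the longer chain shifts the number.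

With only 3-hydroxypropyl and 4-hydroxybutyl to compare, a single step cannot establish a trend, and the compounds shown leave open whether 2-hydroxyethyl or 5-hydroxypentyl would continue it. They also leave open whether the hydroxy group at the chain end plays any part in this step, a question that a plain butyl chain, or an amine or a carboxylic acid at the chain end, could address.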